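From vinyl to prop-1-en-1-yl on a carbonyl carbon

A few compounds are considered here, and "the series" means these few. Any claim that something is new, unique, unknown or untested is made for them only; others in the source may bear on it.

Compound 1 `C/C=C/C(=O)Nc1cccc(Oc2nc(Nc3ccn(C)n3)nc3c2CSCC3)c1`: > 50000 nM
Compound 2 `C/C=C/C(=O)Nc1cccc(Oc2nc(Nc3cccc(C#N)c3)nc3c2CSCC3)c1`: > 50000 nM
Compound 3 `C=CC(=O)Nc1cccc(Oc2nc(Nc3ccc(OC)nc3)nc3c2CSCC3)c1`: > 50000 nM

All three readings come from an ADME assay on L02 cells (Homo sapiens) for cytotoxicity, read by MTT assay, with a stated time of 72 h (a higher number here means a weaker inhibitor, a lower number a stronger inhibitor), and the record shows (the limit of > 50000 nM in this assay, at which 3 of the 3 values shown sit). For compound 3, > 50000 nM is a limit and not a number.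

Compound 4 `C/C=C/C(=O)Nc1cccc(Oc2nc(Nc3ccc(OC)nc3)nc3c2CSCC3)c1` differs from it by one change: prop-1-en-1-yl in place of vinyl on a carbonyl carbon.

Among the measured compounds shown here, the only measured step, a step that the two limits leave unreadable from compound 1 to compound 2, lies elsewhere on the molecule and gives no size to carry over. Compound 1 already bears prop-1-en-1-yl on a carbonyl carbon, and its > 50000 nM is also a limit. Compound 2 bears it too, and its > 50000 nM is likewise a limit.

No step beyond the scatter is therefore expected, and the estimated step is a number no higher from compound 3 to compound 4 (the limit leaves the size open). Compound 4 is expected near 50000 nM, with an estimated range of 30000 nM to 100000 nM.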

Compound 4, half-maximal inhibitory concentration: > 50000 nM
Compound 4: only a limit was reported; the forecaster's own chance of this, stated with the estimate: 85%; the middle value lies on the limit itself.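

Compound 4 gives > 50000 nM in this assay, which is a limit. No step can be read between compound 4 and compound 1, compound 2 or compound 3. What the four compounds leave open is any ranking among them: the limit of > 50000 nM in this assay, at which 4 of the 4 values shown sit.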